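Removing the Fluorine from the Fused Ring of Compound 2

This account rests on a few compounds, and the source may have more. Where it says the series, first, only, none or still open, it means among the compounds named here.

Compound 2 (`N#Cc1cc(-c2nc3c(F)cccc3s2)ccc1N`) stands lowest of the two numbers recorded in a functional assay on MDA-MB-468 cells (Homo sapiens) for inhibition, with a stated time of 72 h; a lower number here means a stronger inhibitor of growth, a higher number a weaker inhibitor of growth: in that test compound 2 gives 80 nM. Its nearest neighbour is compound 1 (`N#Cc1cc(-c2nc3ccc(F)cc3s2)ccc1N`), which in this assay gives 320 nM, a higher number that lies beyond the usual scatter. Among the compounds with values here, the two compounds differ only in where the fluorine sits on the fused ring system, and no single step between them has been worked out, so only their two values can be compared.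

Compound 3 (`N#Cc1cc(-c2nc3ccccc3s2)ccc1N`) has not yet been measured. It differs from compound 2 by hydrogen in place of fluoro on an aromatic carbon, on an aromatic carbon of a six-membered aromatic ring of carbon only, part of a fused system of two rings. Within the data shown here, with no matching step to lean on, a modest move toward a higher number in this assay is expected, a step of a 1.9-fold higher number from compound 2 to compound 3 (0.27 log units; within the scatter). Compound 3 is estimated at 150 nM, with a range from 60 nM to 400 nM.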

Compound 3, concentration for 50% growth inhibition: 340 nM
Compound 3: the middle estimate sits 2.3-fold (0.36 log units) below what was measured, within the range that was stated.
By their numbers in this assay, from the lowest: compound 2; then compounds 1 and 3 (each within the scatter of the next).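

In this assay, putting hydrogen in place of the fluoro of compound 2 gives a 4.3-fold higher number from compound 2 to compound 3 (0.63 log units; beyond the scatter), so the fluoro at that place accounts for a real part of the growth inhibition seen with compound 2. The fluoro of compound 1, which sits elsewhere on the same ring, shows no such contribution: the same exchange there gives a 1.1-fold higher number from compound 1 to compound 3 (0.03 log units; within the scatter). Within these three compounds, then, the effect of the fluoro depends on where it sits on the ring, and fluoro on this ring does not lower the number wherever it is placed.

Nothing available explains why the two places differ. On these data alone, it also remains open whether chlorine, a methoxy group or an amine at the place the fluoro holds in compound 2 would match that compound or go beyond it.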